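Fluoro in place of trifluoromethyl in a close pair

The source may hold more compounds than are shown below. What is called first, only, known or untested is meant among the compounds shown, and "the series" means these compounds.

In a functional assay (aorta) for inhibition, with Rattus norvegicus as the target, with a stated time of 8 days (a lower number here means a stronger inhibitor, a higher number a weaker inhibitor), compound 1 (`Cc1nsc(-c2ccc(N3CCN(c4cccc(Cl)c4)CC3)nn2)n1`) gives 0.6 nM, and compound 2 (`Cc1nsc(-c2ccc(N3CCN(c4cccc(C(F)(F)F)c4)CC3)nn2)n1`) gives 0.3 nM. Among the compounds with values here, compound 2 therefore stands level with the only other measured compound, within the scatter of repeated measurements. The next compound, compound 3 (`Cc1nsc(-c2ccc(N3CCN(c4cccc(F)c4)CC3)nn2)n1`), has fluoro in place of trifluoromethyl on an aromatic carbon, meta to a large group: fluoro in place of trifluoromethyl on an aromatic carbon. Within the data shown here, one measured step bears on this change, the exchange of chloro for trifluoromethyl at that same place: a 2.0-fold lower number from compound 1 to compound 2 (0.30 log units; within the scatter). That step lies within the scatter. Fluoro itself has not yet been measured on this core, so this single step is limited evidence. No change beyond the scatter is expected in this assay. The estimated step is a 2.0-fold higher number from compound 2 to compound 3 (0.30 log units; within the scatter). Compound 3 is expected at 0.6 nM, with an estimated range of 0.2 nM to 2 nM.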

Compound 3, half-maximal inhibitory concentration: 6 nM
For compound 3 the middle estimate is 10-fold (1.00 log units) below the measured one, and the stated range ends below it.
By their numbers in this assay, from the lowest: compounds 2 and 1 (each within the scatter of the next); then compound 3.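

In this assay the group on this aromatic carbon proves not to be indifferent: fluoro gives a weaker inhibitor than trifluoromethyl (a 20-fold higher number from compound 2 to compound 3 (1.30 log units; beyond the scatter)) and also a weaker one than chloro (a 10-fold higher number from compound 1 to compound 3 (1.00 log units; beyond the scatter)). Chloro and trifluoromethyl had stayed within the scatter of each other, so the earlier compounds alone gave no sign that a change at this place could move the number this far. Nothing available here explains why fluoro parts from the other two groups.

On these data alone, whether a methyl, a methoxy or a bromo group would stand with chloro and trifluoromethyl or with fluoro remains open, as does where a plain hydrogen at this place would fall. As far as these compounds go, it is also open whether the same order of these three groups would hold on a core other than the shared one.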